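The source may hold more compounds than are shown below. What is called first, only, known or untested is meant among the compounds shown, and "the series" means these compounds.

In an ADME assay on microsomes from liver (Homo sapiens) for metabolic stability, with a stated time of 0.5 h, tested at 0.5 mg/mL (a higher number here means that more of the compound is left, a lower number that less of the compound is left), the three measured compounds are these:

Compound 1, `CN(C)C(=O)CCNC(=O)c1cc(-c2ccc(F)cc2)no1`, gives 87%.
Compound 2, `CN(C)C(=O)CCNC(=O)c1cc(-c2cccc(F)c2)no1`, gives > 100%, which is a limit of the assay and not a number.
Compound 3, `CN(C)C(=O)CCNC(=O)c1cc(-c2ccccc2F)no1`, gives > 100%, again a limit of the assay rather than a number.

Compound 3 therefore stands at the top of what this assay reports, and only a limit is known for it; the same holds for one further value shown, as the limit of > 100% in this assay, at which 2 of the 3 values shown sit, makes plain. The step from compound 1 to compound 2 was a number at least 13 percentage points higher from compound 1 to compound 2 (beyond the scatter), and the step from compound 1 to compound 3 was a number at least 13 percentage points higher from compound 1 to compound 3 (beyond the scatter). The step from compound 2 to compound 3 is a step that the two limits leave unreadable from compound 2 to compound 3.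

Compound 4, `CN(C)C(=O)CCNC(=O)c1cc(C2CCCCC2)no1`, differs from compound 3 by cyclohexyl in place of 2-fluorophenyl on an aromatic carbon. For the measured compounds named here, none of the measured steps moves between an aromatic and a non-aromatic ring; all three shift a fluorine around a phenyl ring, so they bear on this change only by showing that the shared core tolerates variation at this place without falling far. Since compound 3 sits at a limit, any number for compound 4 can only be read as equal or lower. The expected step from compound 3 to compound 4 is a number at least 22 percentage points lower from compound 3 to compound 4 (beyond the scatter). Compound 4 is estimated at 78% in this assay, with a range from 50% to 100%.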

Compound 4, percent of the compound remaining: > 100%
Compound 4 was reported as a limit (the forecaster's own chance of this, stated with the estimate: 30%); at least 22 percentage points between middle value and limit.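

In this assay, for the compounds shown here, compound 4 gives > 100% as a limit of the assay and not as a number, so this place on the shared core keeps the reading at the top of the scale even with a non-aromatic ring in place of a phenyl ring, something the fluorine shifts among the earlier compounds could not show. Cyclohexyl in place of 4-fluorophenyl gives a number at least 13 percentage points higher from compound 1 to compound 4 (beyond the scatter) and runs the same way as the two earlier steps away from compound 1, which leaves compound 1 as the only one of the four with a readable number. The steps to compound 4 from compound 2 and from compound 3 cannot be read, because all three compounds sit at the same limit: the limit of > 100% in this assay, at which 3 of the 4 values shown sit.

The limit also leaves open how compound 2, compound 3 and compound 4 would rank among themselves, since any real differences between them lie beyond what this assay reports here. The compounds shown also leave open whether a ring carrying an amine or a carboxylic acid, or a longer chain in place of the ring, would hold the reading at this place.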